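From 4-chlorophenyl to 3-methoxyphenyl in compound 4

The source may report more compounds than this note shows. Statements on the series, on what has been measured and on what is new or still open speak of the compounds shown alone.

Compound 1 `COc1cc(N)c(Cl)cc1NC(=O)C1CCN(Cc2ccc(Cl)cc2)CC1` is the only one of the three measured compounds with a number rather than a limit in a functional assay on the whole organism for antagonist activity, with Mus musculus as the target; a lower number here means that less compound is needed, a higher number that more compound is needed for the effect: compound 1 gives 1.2 mg/kg. Compound 2 `COc1cc(N)c(Cl)cc1NC(=O)C1CCN(Cc2cccc(C#N)c2)CC1` reaches only a limit, and in this assay compound 2 gives > 4 mg/kg. Compound 3 `COc1cc(N)c(Cl)cc1NC(=O)C1CCN(CC2CCC2)CC1` likewise reaches only a limit, and compound 3 gives > 10 mg/kg. Compound 4 `COc1cccc(CN2CCC(C(=O)Nc3cc(Cl)c(N)cc3OC)CC2)c1` has not yet been tested; it differs from compound 1 in one place: 3-methoxyphenyl in place of 4-chlorophenyl on a saturated chain carbon bound to an amine nitrogen in a ring. Two measured steps replace the same group: an at least 3.3-fold higher number from compound 1 to compound 2 (0.52 log units; beyond the scatter) and an at least 8.3-fold higher number from compound 1 to compound 3 (0.92 log units; beyond the scatter). Both raised the number beyond the scatter, so a higher number is expected for compound 4 as well, with a real chance that only a limit is reported. The estimate for compound 4 is 4 mg/kg, between 1.5 mg/kg and 12 mg/kg, which is expected to mean a 3.3-fold higher number from compound 1 to compound 4 (0.52 log units; beyond the scatter).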

Compound 4, dose for half-maximal effect: > 4 mg/kg
Compound 4 gave a limit, no number (the forecaster's own chance of this, stated with the estimate: 50%); the middle value sits exactly at the limit.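

In this assay, 3-methoxyphenyl in place of 4-chlorophenyl gives an at least 3.3-fold higher number from compound 1 to compound 4 (0.52 log units; beyond the scatter). Among the compounds shown here, a methoxy-bearing ring thus joins the nitrile-bearing ring and cyclobutyl in falling short of 4-chlorophenyl, leaving compound 1 as the only compound with a number rather than a limit. The steps among compound 2, compound 3 and compound 4 cannot be read, and compound 4 shares its limit with compound 2: the limit of > 4 mg/kg in this assay, at which 2 of the 4 values shown sit.

Still open, from the compounds shown here alone, is whether the chlorine itself or its place on the ring matters, since the group and its place changed together here. 3-Chlorophenyl and 4-methoxyphenyl would separate the two.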